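The compounds below may be only part of what the source reports. "The series", "measured", "known", "first", "only" and "open" are said of these compounds alone.

Measured compounds in a functional assay on T47D cells (Homo sapiens) for inhibition, read by CCK-8 assay, with a stated time of 72 h, tested at 10 uM; on this read-out lower numbers stand for less inhibition of growth and higher numbers for more inhibition of growth at the one concentration tested:
compound 1 `Cc1cccc(NC(=O)C2(C(=O)Nc3ccc(Nc4ncc5cc(C(=O)N(C)C)n(C6CCCC6)c5n4)cc3)CC2)c1`: 95.3%
compound 2 `CN(C)C(=O)c1cc2cnc(Nc3ccc(NC(=O)C4(C(=O)Nc5ccc(Cl)cc5)CC4)cc3)nc2n1C1CCCC1`: 95%
compound 3 `CN(C)C(=O)c1cc2cnc(Nc3ccc(NC(=O)C4(C(=O)Nc5cccc(C(F)(F)F)c5)CC4)cc3)nc2n1C1CCCC1`: 92.7%

Compound 1 gives the highest of the three numbers, but the steps of a number 0.3 percentage points lower from compound 1 to compound 2 (within the scatter) and a number 2.6 percentage points lower from compound 1 to compound 3 (within the scatter) are both within the scatter, as is a number 2.3 percentage points lower from compound 2 to compound 3 (within the scatter); the three amide-side aryl groups tried so far cannot be told apart on this read-out.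

Compound 4 `COc1cccc(NC(=O)C2(C(=O)Nc3ccc(Nc4ncc5cc(C(=O)N(C)C)n(C6CCCC6)c5n4)cc3)CC2)c1` differs from compound 1 only at the aryl amide end: methoxy in place of methyl on an aromatic carbon. Within the data shown here, the step that bears most directly on this change is the one from compound 1 to compound 3, in which another group replaced the methyl on the same aromatic carbon, a number 2.6 percentage points lower from compound 1 to compound 3 (within the scatter). The two steps that swap the whole aryl group, a number 0.3 percentage points lower from compound 1 to compound 2 (within the scatter) and a number 2.3 percentage points lower from compound 2 to compound 3 (within the scatter), are likewise within the scatter. Nothing shown suggests that a change at this position moves the read-out beyond the scatter, so the step from compound 1 to compound 4 is expected to be small, a number 1.3 percentage points lower from compound 1 to compound 4 (within the scatter).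

For compound 4 the estimated value in this assay is 94%, expected to fall between 86% and 99%.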

Compound 4, percent growth inhibition at one concentration: 93.5%
Beside the measured number, compound 4's estimate is 0.5 percentage points above it; low and high end bracket the measured number.
By their numbers in this assay, from the lowest: compounds 3, 4, 2 and 1 (each within the scatter of the next).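

In this assay the methoxy group, which brings one hydrogen-bond acceptor where methyl has none, gives a number 1.8 percentage points lower from compound 1 to compound 4 (within the scatter) at this aromatic carbon, so the extra oxygen and acceptor leave the read-out within the scatter. The same carbon also tolerates methoxy in place of trifluoromethyl, with a number 0.8 percentage points higher from compound 3 to compound 4 (within the scatter) on this read-out, and the swap of 4-chlorophenyl for 3-methoxyphenyl gives a number 1.5 percentage points lower from compound 2 to compound 4 (within the scatter) here, so the four aryl ends cannot be told apart. Nothing measured here offers a reason for this flat picture.

Going by these compounds, whether an amine or a carboxylic acid on this aryl ring would move the number beyond the scatter remains open. Also open, on these data alone, is whether these compounds separate at concentrations lower than the single one used in this assay for this series.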